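Methyl to chloro on the benzyl ring, maximal response

A few compounds are considered here, and "the series" means these few. Any claim that something is new, unique, unknown or untested is made for them only; others in the source may bear on it.

Measured so far:
compound 1 `CCN(Cc1ccccc1)C(=O)C1CCN(S(=O)(=O)c2ccc3cn[nH]c3c2)CC1` — in a functional assay on CHO cells for positive allosteric modulation of muscarinic acetylcholine receptor M5 (Homo sapiens), read by calcium flux (a lower number here means a smaller maximal response, a higher number a larger maximal response), compound 1 gives 86%
compound 2 `CCN(Cc1cccc(OC)c1)C(=O)C1CCN(S(=O)(=O)c2ccc3cn[nH]c3c2)CC1` — compound 2 gives 85%
compound 3 `CCN(Cc1ccccc1C)C(=O)C1CCN(S(=O)(=O)c2ccc3cn[nH]c3c2)CC1` — compound 3 gives 103%

Compound 3 stands highest of the three: a number 17 percentage points higher from compound 1 to compound 3 (beyond the scatter) and a number 18 percentage points higher from compound 2 to compound 3 (beyond the scatter), both beyond the scatter, whereas a number 1 percentage points lower from compound 1 to compound 2 (within the scatter) stays within it.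

Compound 4 `CCN(Cc1ccccc1Cl)C(=O)C1CCN(S(=O)(=O)c2ccc3cn[nH]c3c2)CC1` differs from compound 3 in one place: chloro in place of methyl on an aromatic carbon. Among the compounds with values here, no measured step swaps methyl for chloro; the steps that bear on it are a number 17 percentage points higher from compound 1 to compound 3 (beyond the scatter), which shows the gain from the methyl, and a number 1 percentage points lower from compound 1 to compound 2 (within the scatter), which shows no gain from a methoxy on another position. A one-atom substituent remaining at the same position suggests much of the effect is kept, so only a small step, if any, is expected: a number 6 percentage points lower from compound 3 to compound 4 (within the scatter). Compound 4 is estimated at 97%, with a range from 82% to 110%.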

Compound 4, largest response reached (reported as percent of maximum), in percent of the reference or control that the assay uses: 93%
Compound 4: the middle estimate sits 4 percentage points above what was measured, and the stated range covers the measured number.
By their numbers in this assay, from the lowest: compounds 2, 1, 4 and 3 (each within the scatter of the next, the first and the last beyond it).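

In this assay, the 2-chlorobenzyl compound cannot be separated from any of the other three, with a number 10 percentage points lower from compound 3 to compound 4 (within the scatter) and a number 7 percentage points higher from compound 1 to compound 4 (within the scatter) and a number 8 percentage points higher from compound 2 to compound 4 (within the scatter). The gain beyond the scatter seen with methyl on this aromatic carbon, ortho to a large group, is therefore not clearly repeated with chloro, yet chloro and methyl cannot be told apart here. No measurement at hand bears on why this is so. From the compounds shown here alone, how an ethyl group or an amine at this place would read remains open.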